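The source may hold more compounds than are shown below. What is called first, only, known or untested is meant among the compounds shown, and "the series" means these compounds.

Working notes on the series.

The read-out throughout is a functional assay on HeLa cells for agonist activity at 5-hydroxytryptamine receptor 6 (Homo sapiens), read by cAMP accumulation and immunoassay; on this read-out lower numbers stand for smaller maximal responses and higher numbers for larger maximal responses. Three compounds have numbers. Compound 1 `O=S(=O)(c1cccc(Br)c1)c1cn(C2CCNC2)c2ncccc12` gives 49% in this assay. Compound 2 `O=S(=O)(C1=C(Cl)NC2SC=CN12)c1cn(C2CCNC2)c2ncccc12` gives 32% in this assay. Compound 3 `CC(C)N1CCCC(n2cc(S(=O)(=O)c3cccc(F)c3)c3cccnc32)C1` gives 67% in this assay. Compound 2 therefore stands lowest of the three; compound 1 lies beyond the scatter above it, and compound 3 lies furthest above it, also beyond the scatter. Among the compounds with values here, no single-point step between two measured compounds is available, so none of these gaps can be assigned to one structural change.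

Compound 4 `O=S(=O)(C1=C(Cl)NC2SC=CN12)c1cn(C2CCCNC2)c2ncccc12` is the next compound, not yet measured. It differs from compound 2 by piperidin-3-yl in place of pyrrolidin-3-yl on an aromatic nitrogen. Compound 3 also carries a piperidin-3-yl on the aromatic nitrogen, but its other parts differ from compound 2 as well, so compound 3 gives no clean reading of the ring-size change on its own.

For compound 4 a small step from compound 2 is expected in this assay, a number 8 percentage points higher from compound 2 to compound 4 (within the scatter), pointing upward but not clearly beyond the scatter. The maximal response of compound 4 in this assay is estimated at 40%, with a range from 22% to 60%.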

Compound 4, largest response reached (Emax), in percent of the reference or control that the assay uses: 47%
Estimate against measurement, compound 4: 7 percentage points below, and the stated range covers the measured number.
By their numbers in this assay, from the lowest: compound 2; then compounds 4 and 1 (each within the scatter of the next); then compound 3.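

Within the data shown here, the ring on the aromatic nitrogen is the first position that can be read through a single change: in this assay, piperidin-3-yl in place of pyrrolidin-3-yl gives a number 15 percentage points higher from compound 2 to compound 4 (beyond the scatter), with everything else in the molecule held constant. Among these compounds, the maximal response at this position therefore responds to ring size alone, something the earlier compounds could not show, since they differed from one another in more than one place. The change replaces a five-membered non-aromatic ring with a six-membered one and leaves the counts of hydrogen-bond donors and acceptors and the net charge as they were, while no measurement in hand accounts for the step.

Among the compounds shown here, it remains open whether the same ring change gives a step of similar size with the other group of compound 1, as this single pair rests on the one shared core of compound 2 and compound 4. Also open, from the compounds shown here alone, is whether the response continues to follow ring size with an azepane ring at this position, or how it changes with an open-chain aminoalkyl group there.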